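Removing One Chain Methyl From Compound 2

This account rests on a few compounds, and the source may have more. Where it says the series, first, only, none or still open, it means among the compounds named here.

In a functional assay on MT4 cells (Homo sapiens) for cytotoxicity (on this read-out higher numbers stand for lower toxicity in this test and lower numbers for higher toxicity in this test), compound 1 (`CSc1nc(O)cc(C(C)c2c(F)cccc2F)n1`) gives 20800 nM and compound 2 (`CCC(c1cc(O)nc(SC(C)C)n1)c1c(F)cccc1F`) gives 130000 nM as its value. Compound 2 therefore holds the higher of the two numbers, and the gap lies beyond the usual scatter. Compound 3 (`CC(C)Sc1nc(O)cc(C(C)c2c(F)cccc2F)n1`) has yet to be measured. Within the data shown here, its single change hydrogen in place of methyl on a saturated chain carbon, two bonds along the chain from two aromatic carbons is hydrogen in place of methyl on a saturated chain carbon, two bonds along the chain from two aromatic carbons, so ethyl becomes methyl. Among the measured compounds shown here, no measured pair isolates this change. Compound 3 does share that chain methyl with compound 1, which stands at 20800 nM in this assay and so suggests a partial move toward the lower number. The expected change is a 2.6-fold lower number from compound 2 to compound 3 (0.41 log units; beyond the scatter) as a modest fall, probably just beyond the scatter. For compound 3 the estimated value is 50000 nM with 15000 nM to 170000 nM as the expected range.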

Compound 3, half-maximal cytotoxic concentration: 167000 nM
Estimate against measurement, compound 3: 3.3-fold (0.52 log units) below, and the stated range covers the measured number.
By their numbers in this assay, from the lowest: compound 1; then compounds 2 and 3 (each within the scatter of the next).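

In this assay, ethyl becoming methyl on a saturated chain carbon, two bonds along the chain from two aromatic carbons, gives a 1.3-fold higher number from compound 2 to compound 3 (0.11 log units; within the scatter), so the two compounds cannot be told apart on this read-out. Compound 3 also gives the sulfur a step of its own: with the chain methyl held in common, isopropyl in place of methyl on a sulfur gives an 8.0-fold higher number from compound 1 to compound 3 (0.90 log units; beyond the scatter), which points to the sulfur group, not the chain carbon, as the place where this small set separates. Nothing at hand gives a reason for either step.

Going by these compounds, it remains open whether ethyl and methyl on the chain carbon would also stay within the scatter with a methyl on the sulfur. On these data alone, how a propyl chain on that carbon, or a cyclopropyl group or an amine on the sulfur, would read in this assay is also open.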